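Methoxy Added to the Shared Core: What to Expect

This account rests on a few compounds, and the source may have more. Where it says the series, first, only, none or still open, it means among the compounds named here.

Of the compounds shown here, three built on one shared core have been tested in a functional assay on SW480 cells (Homo sapiens) for inhibition, read by CCK-8 assay, with a stated time of 72 h, tested at 20 uM; a lower number here means less inhibition of growth, a higher number more inhibition of growth at the concentration tested. Compound 1 `CCOC(=O)/C=C1/C(=O)Nc2ccccc21` gives 78.3%. Compound 2 `CC(C)(C)OC(=O)/C=C1/C(=O)Nc2ccccc21` gives 78.1%, and compound 3 `CC(C)(C)OC(=O)/C=C1/C(=O)N(Cc2ccccc2)c2ccccc21` gives 78.4%. Among these three numbers compound 2 stands lowest, but the gaps are tiny: a number 0.2 percentage points lower from compound 1 to compound 2 (within the scatter) and a number 0.3 percentage points higher from compound 2 to compound 3 (within the scatter), so the three values cannot be told apart.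

Compound 4 `COc1ccc2c(c1)NC(=O)/C2=C/C(=O)OC(C)(C)C` has not yet been measured. It differs from compound 2 in one place: methoxy in place of hydrogen on an aromatic carbon. Neither measured step touches the aromatic ring. The first exchanges tert-butyl for ethyl on the ester oxygen, the second puts benzyl in place of hydrogen on the amide-type nitrogen, and both left growth inhibition unchanged within the scatter. Among the measured compounds shown here, no measured step therefore speaks directly to a methoxy on the aromatic ring. For the measured compounds named here, the only guidance is that the core has so far tolerated changes at two different places without any shift, so the expected step is a number 2.1 percentage points lower from compound 2 to compound 4 (within the scatter), that is, nothing beyond the scatter. Compound 4 is therefore expected to give 76%, with a range from 60% to 88%. Going by the values given here, the range is kept wide; no measured step covers this kind of change.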

Compound 4, percent growth inhibition at one concentration: 78.8%
Estimate against measurement, compound 4: 2.8 percentage points below; measured number inside the range.
By their numbers in this assay, from the lowest: compounds 2, 1, 3 and 4 (each within the scatter of the next).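

In this assay, methoxy in place of hydrogen on this aromatic carbon gives a number 0.7 percentage points higher from compound 2 to compound 4 (within the scatter), so the single concentration tested does not tell the two compounds apart. Among the compounds shown here, the earlier steps touched only the ester oxygen and the amide-type nitrogen, so this is the first reading from the aromatic ring of the shared core, and it shows that this carbon, meta to a fused ring and para to a fused ring, can carry methoxy with no shift beyond the scatter. The data offer no measurement that could explain why the number stays put here.

Still open, on these data alone, is whether an amine or a carboxylic acid on this same aromatic carbon would also leave the number within the scatter, and whether a longer chain such as butoxy in place of methoxy would do the same. Also open, as far as these compounds go, are methoxy on the other carbons of this ring and whether the compounds would separate at a lower concentration, where a difference hidden at the one concentration tested might appear.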